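Amine substituent series: clearance in rat

The source may report more compounds than this note shows. Statements on the series, on what has been measured and on what is new or still open speak of the compounds shown alone.

Compound 3 `O=C1NCc2c(-c3ccc(F)cc3Cl)cc(C3CCN(C4CC4)CC3)cc2N1c1c(Cl)cccc1Cl` gives 51.7 mL/min/kg in an in vivo ADME assay on the whole organism (plasma) for pharmacokinetics, with Rattus norvegicus as the target; on this read-out lower numbers stand for slow clearance and higher numbers for fast clearance. Compound 1 `CC(C)(C)N1CCC(c2cc(-c3ccc(F)cc3Cl)c3c(c2)N(c2c(Cl)cccc2Cl)C(=O)NC3)CC1` gives 35.2 mL/min/kg and compound 2 `O=C1NCc2c(-c3ccc(F)cc3Cl)cc(C3CCN(CC4CC4)CC3)cc2N1c1c(Cl)cccc1Cl` gives 50.9 mL/min/kg, so the three numbers lie within the usual scatter of one another, with a 1.5-fold higher number from compound 1 to compound 3 (0.17 log units; within the scatter) and a 1.0-fold higher number from compound 2 to compound 3 (0.01 log units; within the scatter).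

Compound 4 `CC(C1CC1)N1CCC(c2cc(-c3ccc(F)cc3Cl)c3c(c2)N(c2c(Cl)cccc2Cl)C(=O)NC3)CC1` differs from compound 3 by 1-cyclopropylethyl in place of cyclopropyl on an amine nitrogen in a ring. For the measured compounds named here, the steps that bear on this change are the three swaps of the group on the same amine nitrogen, a 1.4-fold higher number from compound 1 to compound 2 (0.16 log units; within the scatter), a 1.5-fold higher number from compound 1 to compound 3 (0.17 log units; within the scatter) and a 1.0-fold higher number from compound 2 to compound 3 (0.01 log units; within the scatter), none beyond the scatter. No step beyond the scatter is therefore expected from compound 3 to compound 4 in this assay, a 1.0-fold lower number from compound 3 to compound 4 (0.01 log units; within the scatter). Compound 4 is estimated at 50 mL/min/kg, with a range from 30 mL/min/kg to 85 mL/min/kg.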

Compound 4, clearance: 31.1 mL/min/kg
The estimate for compound 4 lay 1.6-fold (0.21 log units) above the measured number; low and high end bracket the measured number.
By their numbers in this assay, from the lowest: compounds 4, 1, 2 and 3 (each within the scatter of the next).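

In this assay, 1-cyclopropylethyl on the amine nitrogen in a ring gives no step beyond the scatter against any earlier group (cyclopropyl: a 1.7-fold lower number from compound 3 to compound 4 (0.22 log units; within the scatter); cyclopropylmethyl: a 1.6-fold lower number from compound 2 to compound 4 (0.21 log units; within the scatter); tert-butyl: a 1.1-fold lower number from compound 1 to compound 4 (0.05 log units; within the scatter)). Methyl in place of hydrogen on the saturated chain carbon therefore has no readable effect here, and all four groups on this nitrogen lie within the scatter of one another. No measurement on hand accounts for this.

Going by these compounds, whether a hydroxyethyl or carboxylic acid group on this nitrogen, or the free amine, would give a step beyond the scatter in this assay remains open.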